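This account rests on a few compounds, and the source may have more. Where it says the series, first, only, none or still open, it means among the compounds named here.

Measured compounds, with their readings in a functional assay on A-375 cells (Homo sapiens) for antiproliferative activity, read by CCK-8 assay, with a stated time of 72 h, tested at 2 uM; a higher number here means a stronger effect of the compound at the concentration tested, a lower number a weaker effect:

compound 1, `Nc1ccccc1NC(=O)c1ccc(CSC(=S)N2CCN(Cc3ccccn3)CC2)cc1`: 20.7%
compound 2, `COc1ccc(N2CCN(C(=S)SCc3ccc(C(=O)Nc4ccccc4N)cc3)CC2)cc1`: 28.1%
compound 3, `Nc1ccccc1NC(=O)c1ccc(CSC(=S)N2CCN(Cc3ccccc3)CC2)cc1`: 10.6%

Compound 3 stands lowest of the three numbers in this assay. Its nearest neighbour is compound 1, lying a step beyond the scatter above it, and the furthest is compound 2, a larger step above it, both steps being counted as modest.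

Compound 4, `Nc1ccccc1NC(=O)c1ccc(CSC(=S)N2CCN(c3cnccn3)CC2)cc1`, has not yet been measured. It differs from compound 3 in one place: pyrazin-2-yl in place of benzyl on an amine nitrogen in a ring. Going by the values given here, two measured steps bear on this change. The step of a number 17.5 percentage points lower from compound 2 to compound 3 (beyond the scatter) shows what happens when an aryl group on the ring nitrogen is replaced by benzyl, so the reverse direction, aryl in place of benzyl, points upward. The step of a number 10.1 percentage points lower from compound 1 to compound 3 (beyond the scatter) shows that taking an aromatic nitrogen out of the group on the ring nitrogen lowers the reading, so putting aromatic nitrogens in points upward as well. A modest rise in this assay is therefore expected for compound 4, and compound 4 is estimated at 25%, with a range from 12% to 40%. Among the compounds with values here, the expected step is a number 14.4 percentage points higher from compound 3 to compound 4 (beyond the scatter), though no measured compound carries pyrazin-2-yl itself, so the range is kept wide.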

Compound 4, a percentage reported as inhibition, at one concentration (the size of the read-out at that concentration, not a potency): 29.1%
For compound 4 the middle estimate is 4.1 percentage points below the measured one; the range from low to high includes it.
By their numbers in this assay, from the lowest: compound 3; then compounds 1, 2 and 4 (each within the scatter of the next).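

In this assay, pyrazin-2-yl on the amine nitrogen in the ring gives a number 18.5 percentage points higher from compound 3 to compound 4 (beyond the scatter) when it takes the place of benzyl, so a second aryl group, after the 4-methoxyphenyl of compound 2, stands clear of benzyl at this position. The methoxy group and a ring of carbon only are therefore not needed for that difference, since the exchange of 4-methoxyphenyl for pyrazin-2-yl gives a number 1 percentage points higher from compound 2 to compound 4 (within the scatter) and leaves the two groups indistinguishable in this assay. The exchange of (pyridin-2-yl)methyl for pyrazin-2-yl gives a number 8.4 percentage points higher from compound 1 to compound 4 (within the scatter) as well, so among these compounds only the benzyl group of compound 3 stands apart, while the three groups that carry aromatic nitrogen or methoxy cannot be ranked against one another. The data offer no explanation for these differences.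

As far as these compounds go, it remains open whether a pyrimidin-2-yl or a plain phenyl group on the same nitrogen would read like compound 4, and whether an amine or a carboxylic acid on the pyrazine ring would change the reading. From the compounds shown here alone, all of these readings come from one concentration, so the potency of compound 4 also remains open.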